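The source may report more compounds than this note shows. Statements on the series, on what has been measured and on what is new or still open speak of the compounds shown alone.

In a physicochemical assay for lipophilicity, measured as octanol-water partition (on this read-out lower numbers stand for lower lipophilicity and higher numbers for higher lipophilicity), compound 1 `C/C(CC(=O)Nc1nnc(-c2ccc([N+](=O)[O-])cc2)s1)=N\c1ccc([N+](=O)[O-])cn1` gives 3.54. Compound 2 `C/C(CC(=O)Nc1nnc(-c2ccc([N+](=O)[O-])cc2)s1)=N\c1ccccn1` gives 3.63 and compound 3 `CC(=O)Oc1ccccc1-c1nnc(NC(=O)C/C(C)=N/c2ccccn2)s1` gives 3.65, so all three values sit within the scatter of one another and compound 1 cannot be set apart from them. Compound 4 `C/C(CC(=O)Nc1nnc(-c2ccc(N)cc2)s1)=N\c1ccc([N+](=O)[O-])cn1` differs from compound 1 in one place: amino in place of nitro on an aromatic carbon. Going by the values given here, the only measured step that touches the nitro group is a number 0.09 log units higher from compound 1 to compound 2 (within the scatter), where hydrogen rather than amino took its place, so no measured step covers this exact change. For compound 4 in this assay a decrease beyond the scatter is nonetheless expected, a number 0.64 log units lower from compound 1 to compound 4 (beyond the scatter). Compound 4 is estimated at 2.9, with a range from 2.4 to 3.4.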

Compound 4, partition coefficient: 3.21
The estimate for compound 4 lay 0.31 log units below the measured number; measured number inside the range.
By their numbers in this assay, from the lowest: compound 4; then compounds 1, 2 and 3 (each within the scatter of the next).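

In this assay, changing 4-nitrophenyl to 4-aminophenyl gives a number 0.33 log units lower from compound 1 to compound 4 (beyond the scatter), a modest step but one beyond the scatter. The earlier step, a number 0.09 log units higher from compound 1 to compound 2 (within the scatter), replaced a different nitro group with hydrogen and stayed within the scatter, so this is the first change shown that separates two compounds on this read-out. Nothing measured here explains the step.

Going by these compounds, how a carboxylic acid or a methoxy group at this position would compare remains open. So does whether the same swap gives a similar step on compound 2.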